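This account rests on a few compounds, and the source may have more. Where it says the series, first, only, none or still open, it means among the compounds named here.

Working notes on the series. In an assay on isolated protein for inhibition of Polyunsaturated fatty acid 5-lipoxygenase (Homo sapiens) (a lower number here means a stronger inhibitor, a higher number a weaker inhibitor), compound 1 `COC1(c2cccc(COc3ccc4ccccc4c3)c2)CCOCC1` gives 1500 nM, the higher of the two numbers recorded so far. The other measured compound, compound 2 `CC(c1ccc(OCc2ccccc2)cc1)N(O)C(N)=O`, gives 360 nM in this assay, a lower number that lies beyond the scatter of compound 1; since it differs from compound 1 in more than one place, nothing further is drawn from the pair.

Compound 3 `c1ccc(COc2ccc3ccccc3c2)cc1` is the unmeasured compound. It differs from compound 1 in one place: hydrogen in place of 4-methoxyoxan-4-yl on an aromatic carbon. Among the measured compounds shown here, no single-change step between measured compounds is available to calibrate this cut, so the expectation rests on compound 1 alone. The loss of the larger group is expected to give a higher number, a step of a 3.3-fold higher number from compound 1 to compound 3 (0.52 log units; beyond the scatter), beyond the scatter. For compound 3 in this assay the estimate is 5000 nM, with a range from 1500 nM to 20000 nM.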

Compound 3, half-maximal inhibitory concentration: 7500 nM
Estimate against measurement, compound 3: 1.5-fold (0.18 log units) below; low and high end bracket the measured number.
By their numbers in this assay, from the lowest: compound 2; then compound 1; then compound 3.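

In this assay, among the compounds shown here, the first readable single change is a 5.0-fold higher number from compound 1 to compound 3 (0.70 log units; beyond the scatter) when hydrogen replaces 4-methoxyoxan-4-yl on the aromatic carbon, so the group at this position, meta to a large group, contributes to inhibition beyond the scatter. The core does not depend on the group for all of its measurable inhibition, since compound 3 still gives 7500 nM in this assay. Nothing at hand explains the size of this step.

As far as these compounds go, it remains open whether the full 4-methoxyoxan-4-yl group is needed at this carbon, or whether a simple methoxy group or an oxane ring without the methoxy group would serve as well. The effect of an amine or a carboxylic acid at the same carbon is also unknown.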